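The compounds below may be only part of what the source reports. "The series", "measured", "known", "first", "only" and "open" are said of these compounds alone.

Measured so far in a functional assay on L1210 cells (Mus musculus) for cytotoxicity, read by cell counting, with a stated time of 2 days; a lower number here means a stronger inhibitor, a higher number a weaker inhibitor:
Compound 1 `C=C(Br)C(=O)Nc1ccc(/C=C2\SC(=O)N(Cc3ccc(C)cc3)C2=O)cc1` gives 3400 nM.
Compound 2 `Nc1cccc(/C=C2\SC(=O)N(Cc3cccc(F)c3)C2=O)c1` gives 199000 nM.
Compound 3 `Nc1ccc(/C=C2\SC(=O)N(Cc3cccc(F)c3)C2=O)cc1` gives 100000 nM.

Compound 2 thus has the highest number of the three. Its nearest neighbour is compound 3, reached by a 2.0-fold lower number from compound 2 to compound 3 (0.30 log units; within the scatter), a step within the scatter, while the gap to compound 1 is far wider than the scatter.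

Compound 4 `Nc1cccc(/C=C2\SC(=O)N(Cc3cccc(Cl)c3)C2=O)c1` differs from compound 2 by chloro in place of fluoro on an aromatic carbon. Among the compounds with values here, no measured step bears on this change: the only step available, a 2.0-fold lower number from compound 2 to compound 3 (0.30 log units; within the scatter), concerns a different part of the molecule and says nothing about the halogen. With no guidance from the data, no step beyond the scatter is expected in this assay in either direction. Compound 4 is therefore estimated at 180000 nM, with a range from 80000 nM to 400000 nM, which corresponds to an expected 1.1-fold lower number from compound 2 to compound 4 (0.04 log units; within the scatter).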

Compound 4, half-maximal inhibitory concentration: 211000 nM
Compound 4: the middle estimate sits 1.2-fold (0.07 log units) below what was measured; low and high end bracket the measured number.
By their numbers in this assay, from the lowest: compound 1; then compounds 3, 2 and 4 (each within the scatter of the next, the first and the last beyond it).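

Within the data shown here, exchanging 3-fluorophenyl for 3-chlorophenyl gives the first reading on this halogen position in this assay (a 1.1-fold higher number from compound 2 to compound 4 (0.03 log units; within the scatter)). With the 3-aminophenyl group in place, the two halogens therefore cannot be told apart here, and the number of compound 4 stays as high as that of compound 2. No supporting data bear on this result.

From the compounds shown here alone, what a bromo, methoxy or trifluoromethyl group would give on this aromatic carbon remains open. So does whether chloro and fluoro also stay level on compound 3, which carries 4-aminophenyl.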